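A 3-Methoxyphenyl Group on the Aromatic Nitrogen

The source may report more compounds than this note shows. Statements on the series, on what has been measured and on what is new or still open speak of the compounds shown alone.

In a functional assay on A549 cells (Homo sapiens) for inhibition, read by MTT assay, with a stated time of 72 h (a higher number here means a weaker inhibitor, a lower number a stronger inhibitor), compound 1 (`Cc1cc2occ(-c3nc(-c4ccccc4)c(-c4ccccc4)n3-c3ccc(Cl)cc3)c(=O)c2cc1Cl`) gives 12500 nM, and compound 2 (`Cc1cc2occ(-c3nc(-c4ccccc4)c(-c4ccccc4)n3-c3ccccc3Cl)c(=O)c2cc1Cl`) gives 12500 nM, which places it level with compound 1. Compound 3 (`COc1cccc(-n2c(-c3coc4cc(C)c(Cl)cc4c3=O)nc(-c3ccccc3)c2-c2ccccc2)c1`) carries 3-methoxyphenyl in place of 2-chlorophenyl on an aromatic nitrogen. Within the data shown here, only one measured step bears on this change, and it concerns the same nitrogen: no change at the digits printed from compound 1 to compound 2 (within the scatter). Among the measured compounds shown here, that step exchanged one chlorophenyl group for another, and no compound with a 3-methoxyphenyl group has been measured, so it offers only limited guidance. On this evidence, no step beyond the scatter is expected in this assay, in either direction. The estimated step is a 1.0-fold lower number from compound 2 to compound 3 (0.02 log units; within the scatter). For compound 3, the expected value is 12000 nM, with an estimated range from 5000 nM to 30000 nM.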

Compound 3, half-maximal inhibitory concentration: 6250 nM
The estimate for compound 3 lay 1.9-fold (0.28 log units) above the measured number; measured number inside the range.
By their numbers in this assay, from the lowest: compounds 3, 1 and 2 (each within the scatter of the next).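

In this assay, 3-methoxyphenyl in place of 2-chlorophenyl on the aromatic nitrogen gives a 2.0-fold lower number from compound 2 to compound 3 (0.30 log units; within the scatter), and 3-methoxyphenyl in place of 4-chlorophenyl gives a 2.0-fold lower number from compound 1 to compound 3 (0.30 log units; within the scatter). The earlier compounds shown here varied only a chlorophenyl group, whereas compound 3 shows that a group without chlorine and with one hydrogen-bond acceptor can stand at this nitrogen with no step beyond the scatter. Nothing available here accounts for these numbers. The compounds shown leave open whether any group on this nitrogen can move the number beyond the scatter, such as a phenyl ring carrying an amine or a carboxylic acid. They also say nothing about changes elsewhere on the shared core, since all three compounds differ only at this nitrogen.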